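This account rests on a few compounds, and the source may have more. Where it says the series, first, only, none or still open, it means among the compounds named here.

Working notes on the series. The shared core of compound 1 `CCOC(=O)/C=C/c1ccncc1-c1ccc2c(cnn2C)c1` carries an ethoxycarbonyl group on the ethenyl chain. In an assay on a protein complex for inhibition of CDK8/Cyclin C (Homo sapiens), with a stated time of 1 h (on this read-out lower numbers stand for stronger inhibition and higher numbers for weaker inhibition), compound 1 gives 102 nM. Compound 2 `CCOC(=O)/C=C/c1ccncc1-c1ccc2ccccc2c1` keeps the same ester and chain on a different aryl group; in this assay compound 2 gives 53.3 nM, and the two numbers lie within the scatter of each other, so compound 1 and compound 2 are not distinguished here. Compound 3 `NC(=O)/C=C/c1ccncc1Nc1ccc(F)cc1` has the carbamoyl version of the chain on an anilino-substituted core; in this assay compound 3 has "not determined" (no result reported), so it adds no number to the picture.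

Compound 4 `CNC(=O)/C=C/c1ccncc1-c1ccc2c(cnn2C)c1` differs from compound 1 in one place: methylamino in place of ethoxy on a carbonyl carbon. Among the measured compounds shown here, no measured pair in the set makes this change, so the direction has to be taken as open. With nothing to point either way, the step from compound 1 to compound 4 is expected to be small, a 1.5-fold higher number from compound 1 to compound 4 (0.17 log units; within the scatter), and likely not beyond the scatter. Compound 4 is therefore estimated at 150 nM in this assay, with a range from 50 nM to 500 nM.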

Compound 4, half-maximal inhibitory concentration: 86.7 nM
Compound 4: middle estimate off by 1.7-fold (0.24 log units), on the high side; the measured number falls inside the stated range.
By their numbers in this assay, from the lowest: compounds 2, 4 and 1 (each within the scatter of the next).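

The step at this position gives its first reading: with methylamino in place of ethoxy on a carbonyl carbon, this assay shows a 1.2-fold lower number from compound 1 to compound 4 (0.07 log units; within the scatter). On the core of compound 1, the ethoxycarbonyl and methylcarbamoyl forms of the chain are therefore not distinguished, so the ester is not needed to keep a measured number in this range, although this rests on a single pair. No measurement at hand bears on why the two forms read alike.

As far as these compounds go, whether a carboxylic acid, an unsubstituted carbamoyl or a dimethylamino group on the same carbonyl carbon would also read alike remains open. From the compounds shown here alone, it is equally open whether methylamino in place of ethoxy would give a similar step on the aryl group of compound 2.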